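From a Two-Ring Arm Back to a Single Ring

The source may report more compounds than this note shows. Statements on the series, on what has been measured and on what is new or still open speak of the compounds shown alone.

For the measured compounds named here, compound 2 `c1ccc2c(-c3cn4ccnc4c(-c4ccc5ncn(C6CCCCC6)c5c4)n3)cccc2c1` stands lowest of the two numbers so far: in a functional assay on UACC-62 cells (Homo sapiens) for inhibition, read by sulforhodamine B assay, with a stated time of 48 h, tested at 10 uM (a higher number here means more inhibition at the concentration tested (going by the name of the read-out), a lower number less inhibition), compound 2 gives 16.7%, while compound 1 `COc1ccc(-c2cn3ccnc3c(-c3ccc4ncn(C5CCCCC5)c4c3)n2)cc1` gives 65.2%. Going by the values given here, the only measured step is a number 48.5 percentage points lower from compound 1 to compound 2 (beyond the scatter), a large fall. Compound 3 `Fc1ccc(-c2cn3ccnc3c(-c3ccc4ncn(C5CCCCC5)c4c3)n2)cc1` differs from compound 2 in one place: 4-fluorophenyl in place of naphthalen-1-yl on an aromatic carbon. That measured step bears directly on this change. The change largely reverses the move that set compound 2 below compound 1: a single six-membered aromatic ring of carbon only returns, now as 4-fluorophenyl where compound 1 carries 4-methoxyphenyl. A large gain is therefore expected, a number 38.3 percentage points higher from compound 2 to compound 3 (beyond the scatter), though whether fluorine matches methoxy is not settled by the two numbers at hand. For compound 3 the estimate in this assay is 55%, with a likely range from 30% to 75%.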

Compound 3, a percentage reported as inhibition, at one concentration (the size of the read-out at that concentration, not a potency): 31%
The estimate for compound 3 lay 24 percentage points above the measured number, and the stated range covers the measured number.
By their numbers in this assay, from the lowest: compound 2; then compound 3; then compound 1.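

Returning to a single ring at this position recovers only part of the lost inhibition: in this assay, 4-fluorophenyl in place of naphthalen-1-yl gives a number 14.3 percentage points higher from compound 2 to compound 3 (beyond the scatter) and no more. The single ring alone therefore does not account for the higher number of compound 1, since fluoro in place of methoxy on that same ring gives a number 34.2 percentage points lower from compound 1 to compound 3 (beyond the scatter) as a large fall. The group carried on the ring thus matters as well as the ring itself, but no measurement at hand explains this difference.

From the compounds shown here alone, whether a plain phenyl, or the same ring bearing an amine or a hydroxyl group, would fall nearer compound 1 or compound 2 remains open. A longer ether such as ethoxy in place of methoxy is also an untested question among the compounds shown here.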